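The compounds below may be only part of what the source reports. "The series", "measured", "known", "first", "only" and "open" are said of these compounds alone.

Measured so far in an ADME assay on microsomes from liver (Rattus norvegicus) for metabolic stability, read by LC-MS, using NADPH, with stated times of 10 min and 30 min; on this read-out lower numbers stand for slow clearance and higher numbers for fast clearance:
Compound 1 `CCS(=O)(=O)N1CCC(c2cncc(N3C(=O)c4ccc(Cl)cc4C3(C)C)c2)CC1`: 35.1 mL/min/kg
Compound 2 `CC(=O)N[C@@H]1CCCc2c1cncc2N1CCc2cc(Cl)ccc2C1=O`: < 20.2 mL/min/kg (a limit)
Compound 3 `CCC(=O)N[C@@H]1CCCc2c1cncc2N1CCc2cc(Cl)ccc2C1=O`: < 20.2 mL/min/kg (a limit)

Compound 3 has no number in this assay, only the limit < 20.2 mL/min/kg. This is the limit of < 20.2 mL/min/kg in this assay, at which 2 of the 3 values shown sit.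

Compound 4 `CS(=O)(=O)N[C@@H]1CCCc2c1cncc2N1CCc2cc(Cl)ccc2C1=O` is not yet measured. It differs from compound 3 by methylsulfonyl in place of propanoyl on an amine nitrogen. Among the compounds with values here, the one measured step nearby is a step that the two limits leave unreadable from compound 2 to compound 3, so it offers no size to carry over to this change. Compound 1 also bears a sulfonyl group, but on a different core, and its 35.1 mL/min/kg gives only a loose upper guide.

Within the data shown here, with no measured step to suggest otherwise, no shift beyond the scatter is expected in either direction, and the expected step is a step that the limit leaves unreadable from compound 3 to compound 4. A report as a limit is thought slightly more likely than not. For compound 4 the estimate is 18 mL/min/kg, with an expected range from 10 mL/min/kg to 32 mL/min/kg.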

Compound 4, clearance: < 20.2 mL/min/kg
Compound 4: only a limit was reported; the forecaster's own chance of this, stated with the estimate: 60%; the middle value lies beyond the limit too.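

Compound 2, compound 3 and compound 4 all stand only as limits in this assay, so no step among them can be read: the limit of < 20.2 mL/min/kg in this assay, at which 3 of the 4 values shown sit.

The compounds shown leave open whether methylsulfonyl, propanoyl and acetyl on the amine nitrogen differ at all in clearance.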